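Heteroaryl swap on the shared core: outlook for compound 4

This account rests on a few compounds, and the source may have more. Where it says the series, first, only, none or still open, it means among the compounds named here.

Compound 1 `Nc1nc(-c2ncco2)nc2sc(Cc3ccccc3)cc12`: 310 nM in a functional assay on CHO-K1 cells for antagonist activity at adenosine receptor A1 (Homo sapiens), read by a beta-galactosidase reporter and cAMP accumulation, with stated times of 15 min and 6 h; a lower number here means a stronger inhibitor, a higher number a weaker inhibitor
Compound 2 `Nc1nc(-c2cccnc2)nc2sc(Cc3ccccc3)cc12`: 1420 nM
Compound 3 `Nc1nc(-c2ccncc2)nc2sc(Cc3ccccc3)cc12`: 812 nM

Compound 3 gives the second highest of the three numbers. Compound 2 stands nearest, and a 1.7-fold lower number from compound 2 to compound 3 (0.24 log units; within the scatter) lies within the scatter; compound 1 is furthest, with a 2.6-fold higher number from compound 1 to compound 3 (0.42 log units; beyond the scatter) beyond it. Compound 4 `N#Cc1cccc(-c2nc(N)c3cc(Cc4ccccc4)sc3n2)n1` differs from compound 3 by 6-cyanopyridin-2-yl in place of pyridin-4-yl on an aromatic carbon. Among the measured compounds shown here, the steps that bear on this change are the heteroaryl swaps at the same position: a 4.6-fold higher number from compound 1 to compound 2 (0.66 log units; beyond the scatter) and a 2.6-fold higher number from compound 1 to compound 3 (0.42 log units; beyond the scatter), both modest, and a 1.7-fold lower number from compound 2 to compound 3 (0.24 log units; within the scatter). On these data alone, none of them involves a nitrile or a pyridin-2-yl; the direction stays open. A modest step in this assay, in either direction, is expected, a 1.8-fold lower number from compound 3 to compound 4 (0.26 log units; within the scatter). Compound 4 is therefore estimated at 450 nM, with a range of 130 nM to 1500 nM.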

Compound 4, inhibition constant: > 1000 nM
Compound 4 gave a limit, no number; the forecaster's own chance of this, stated with the estimate: 5%; middle value at least 2.2-fold (0.34 log units) away from the limit.
By their numbers in this assay, from the lowest: compound 1; then compounds 3 and 2 (each within the scatter of the next).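

In this assay compound 4 gives only a limit, not a number: the limit of > 1000 nM in this assay, at which 1 of the 4 values shown sits. With 6-cyanopyridin-2-yl in place of 1,3-oxazol-2-yl there is an at least 3.2-fold higher number from compound 1 to compound 4 (0.50 log units; beyond the scatter), so all three pyridine-bearing compounds now give higher numbers than compound 1, with no exception among those shown. Against pyridin-4-yl there is an at least 1.2-fold higher number from compound 3 to compound 4 (0.09 log units; that floor lies within the scatter), so the nitrile-bearing ring shows no gain at this position, while the step involving compound 2 cannot be read.

On these data alone, the true size of the number for compound 4 stays open. Also open, as far as these compounds go, is whether an unsubstituted pyridin-2-yl, or an amine or carboxylic acid in place of the nitrile, would come closer to compound 1.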